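This account rests on a few compounds, and the source may have more. Where it says the series, first, only, none or still open, it means among the compounds named here.

In an ADME assay on microsomes from liver (Rattus norvegicus) for metabolic stability, with a stated time of 10 min (on this read-out higher numbers stand for a more stable compound and lower numbers for a less stable compound), compound 1 `COc1nc(C)c(Nc2nc(Cl)cn([C@H](C)C3CC3)c2=O)cc1C` gives 77%. Among the compounds with values here, compound 2 `Cc1cc(Nc2nc(Cl)cn([C@H](C)C3CC3)c2=O)c(C)nc1N(C)C` gives 54%, the lower of the two numbers so far. The next compound is compound 3 `Cc1cc(Nc2nc(Cl)cn([C@H](C)C3CC3)c2=O)c(C)nc1N1CCCC1`, and its difference from compound 2 is pyrrolidin-1-yl in place of dimethylamino on an aromatic carbon. In words, pyrrolidin-1-yl takes the place of dimethylamino on an aromatic carbon, next to the ring nitrogen. Within the data shown here, only one measured step bears on this change: a number 23 percentage points lower from compound 1 to compound 2 (beyond the scatter), a modest step beyond the scatter, with dimethylamino in place of methoxy on an aromatic carbon. That step starts from a different group, so it offers no direct measure for pyrrolidin-1-yl, and the estimate stays anchored on the measured value of compound 2, which gives 54%. The expected step is a number 8 percentage points lower from compound 2 to compound 3 (within the scatter), a small downward one that may stay within the scatter. Compound 3 is estimated at 46%, with an expected range from 27% to 64%.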

Compound 3, percent of the compound remaining: 57%
For compound 3 the middle estimate is 11 percentage points below the measured one; the range from low to high includes it.
By their numbers in this assay, from the lowest: compounds 2 and 3 (each within the scatter of the next); then compound 1.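

In this assay, pyrrolidin-1-yl in place of dimethylamino on the aromatic carbon next to the ring nitrogen gives a number 3 percentage points higher from compound 2 to compound 3 (within the scatter), so at this position, tying the amine into a five-membered ring and going from 3 to 5 heavy atoms leaves no resolved difference. Pyrrolidin-1-yl in place of methoxy gives a number 20 percentage points lower from compound 1 to compound 3 (beyond the scatter), a gap of much the same size as a number 23 percentage points lower from compound 1 to compound 2 (beyond the scatter), so both amines stand apart from methoxy in these three compounds. No supporting measurement accounts for either step.

Still open, as far as these compounds go, is whether ethoxy stays with compound 1 while morpholin-4-yl or piperidin-1-yl stays with compounds 2 and 3. Also open, from the compounds shown here alone, is whether a smaller amine, such as methylamino with its hydrogen on nitrogen, falls with this pair.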